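The source may report more compounds than this note shows. Statements on the series, on what has been measured and on what is new or still open speak of the compounds shown alone.

Going by the values given here, compound 2 `C=C1CC[C@@H]2[C@](C)(CO[Si](C)(C)C(C)(C)C)[C@H](OC(C)=O)CC[C@@]2(C)[C@@H]1C/C=C1/C(=O)OC[C@H]1OC(C)=O` gives 2.84 uM in a functional assay on MCF7 cells (Homo sapiens) for cytotoxicity, read by sulforhodamine B assay (on this read-out lower numbers stand for an effect already at smaller amounts and higher numbers for an effect only at larger amounts of compound), the lowest of the two numbers measured so far. Among the compounds with values here, the only other measured compound, compound 1 `C=C1CC[C@@H]2[C@](C)(CO[Si](C(C)C)(C(C)C)C(C)C)[C@H](OC(C)=O)CC[C@@]2(C)[C@@H]1C/C=C1/C(=O)OC[C@H]1OC(C)=O`, gives 14 uM; the step of a 4.9-fold lower number from compound 1 to compound 2 (0.69 log units; beyond the scatter) concerns only the silicon-containing group. Compound 3 `C=C1CC[C@@H]2[C@](C)(CO[Si](C)(C)C(C)(C)C)[C@H](O)CC[C@@]2(C)[C@@H]1C/C=C1/C(=O)OC[C@H]1OC(C)=O` differs from compound 2 elsewhere: hydrogen in place of acetyl on an oxygen on a saturated carbon. Within the data shown here, no measured step touches this acetyl, so the change from compound 1 to compound 2 offers no guide, and no step beyond the scatter is expected in this assay. Compound 3 is therefore estimated at 3 uM, with a range from 1 uM to 9 uM. That expected outcome corresponds to a step of a 1.1-fold higher number from compound 2 to compound 3 (0.02 log units; within the scatter).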

Compound 3, concentration for half-maximal effect: 10.4 uM
Beside the measured number, compound 3's estimate is 3.5-fold (0.54 log units) below it; the measured number lies above the stated range.
By their numbers in this assay, from the lowest: compound 2; then compounds 3 and 1 (each within the scatter of the next).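

In this assay, going from acetoxy to hydroxy brings a 3.7-fold higher number from compound 2 to compound 3 (0.56 log units; beyond the scatter), so compound 3 needs more compound for the same effect, and the acetyl on this oxygen matters to the read-out, just as the silicon-containing group did. Nothing at hand explains this shift.

As far as these compounds go, whether a longer ester such as butanoyl, a methyl ether or an amine at this place would hold the number of compound 2 remains open. So does whether losing the acetyl would shift the number by a similar amount with the larger silicon-containing group of compound 1.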